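A Methyl Added to the Weaker of Two Compounds

The source may report more compounds than this note shows. Statements on the series, on what has been measured and on what is new or still open speak of the compounds shown alone.

Measured so far:
compound 1, `Cc1ccc(C(=O)NNC(=S)Nc2csc(-c3ccc(C)cc3)c2)cc1`, gives 37000 nM in a functional assay on A549 cells (Homo sapiens) for inhibition, read by colorimetric assay and MTT assay, with a stated time of 72 h; a lower number here means a stronger inhibitor, a higher number a weaker inhibitor.
compound 2, `O=C(NNC(=S)Nc1csc(-c2ccccc2)c1)c1ccc(O)cc1`, gives 75000 nM in this assay.

Compound 2 holds the higher of the two numbers, and its gap to compound 1 lies beyond the usual scatter, so compound 2 is the weaker inhibitor of the pair. Among the measured compounds shown here, compound 1 and compound 2 differ in two places at once, so no single step connects them.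

Compound 3, `Cc1ccc(-c2cc(NC(=S)NNC(=O)c3ccc(O)cc3)cs2)cc1`, is compound 2 with one change: methyl in place of hydrogen on an aromatic carbon. The resulting 4-methylphenyl group is also present in compound 1, which gives 37000 nM in this assay. On that basis a small shift toward a lower number, or none beyond the scatter, is expected in this assay. Compound 3 is expected to give 50000 nM, with a range from 20000 nM to 120000 nM. The expected step from compound 2 to compound 3 is a 1.5-fold lower number from compound 2 to compound 3 (0.18 log units; within the scatter).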

Compound 3, half-maximal inhibitory concentration: 44000 nM
The estimate for compound 3 lay 1.1-fold (0.06 log units) above the measured number; low and high end bracket the measured number.
By their numbers in this assay, from the lowest: compounds 1, 3 and 2 (each within the scatter of the next, the first and the last beyond it).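

In this assay, methyl in place of hydrogen, which turns phenyl into 4-methylphenyl, gives a 1.7-fold lower number from compound 2 to compound 3 (0.23 log units; within the scatter), so at this place, para to a large group, the added methyl brings no clear difference. Hydroxy in place of methyl on an aromatic carbon, with the 4-methylphenyl group kept, gives a 1.2-fold higher number from compound 1 to compound 3 (0.08 log units; within the scatter), so compound 3 is now linked to each earlier compound by one change, and neither change stands out from the scatter. Nothing available here bears on why these steps have the size they do.

The compounds shown leave open whether a different group at this place, such as an amine, a carboxylic acid or a longer chain, would give a step beyond the scatter. They also leave open whether any such step would hold with hydroxy and with methyl on the other aromatic ring.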